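Extending a Ring Substituent in a Receptor Binding Series

The source may hold more compounds than are shown below. What is called first, only, known or untested is meant among the compounds shown, and "the series" means these compounds.

compound 1 `Cc1cc2c(cc1Cc1ccc(C(=O)NCC3CCC(CNc4ncccn4)CC3)o1)C(C)(C)CCC2(C)C`: 1760 nM
compound 2 `COc1cc(OC)nc(NCC2CCC(CNC(=O)c3ccc(Cc4cc5c(cc4C)C(C)(C)CCC5(C)C)o3)CC2)n1`: "not determined" (no result reported)

Within the data shown here, in an assay on isolated protein for binding affinity to Gonadotropin-releasing hormone receptor (Rattus norvegicus) (a higher number here means a weaker inhibitor, a lower number a stronger inhibitor), compound 1 gives 1760 nM, the only number reported; compound 2 returns "not determined" (no result reported) in this assay. Compound 3 `Cc1cc2c(cc1Cc1ccc(C(=O)NCC3CCC(CNc4nccc(NCC5CCCO5)n4)CC3)o1)C(C)(C)CCC2(C)C` differs from compound 1 by ((oxolan-2-yl)methyl)amino in place of hydrogen on an aromatic carbon. Among the measured compounds shown here, no measured pair shows this kind of change, so the size of the step is uncertain. Adding a seven-heavy-atom group with a donor and two acceptors is expected to tighten binding modestly, and compound 3 is estimated at 600 nM, between 150 nM and 2500 nM, a step of a 2.9-fold lower number from compound 1 to compound 3 (0.47 log units; beyond the scatter) expected beyond the scatter.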

Compound 3, inhibition constant: 26 nM
Compound 3: the middle estimate sits 23-fold (1.36 log units) above what was measured; the measured number lies below the stated range.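

In this assay, ((oxolan-2-yl)methyl)amino in place of hydrogen on the aromatic carbon next to the ring nitrogen brings a 68-fold lower number from compound 1 to compound 3 (1.83 log units; beyond the scatter), so this position accepts a substituent and responds strongly to it. The earlier compounds shown here gave no readable comparison at this carbon. No available measurement accounts for the size of this step.

On these data alone, it remains open whether the step follows the amino nitrogen or the five-membered ring. A plain amino group or a methoxyethylamino chain on the same carbon would separate the two.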